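The source may hold more compounds than are shown below. What is called first, only, known or untested is meant among the compounds shown, and "the series" means these compounds.

Measured compounds:
compound 1 `CCCN(CC[C@H]1CC[C@H](NC(=O)c2cccc3ncccc23)CC1)[C@H]1CCc2nc(N)sc2C1` gives 1.6 nM in an assay on brain for displacement of a labelled ligand from D(3) dopamine receptor (Rattus norvegicus); a higher number here means a weaker inhibitor, a lower number a stronger inhibitor;
compound 2 `CCCN(CC[C@H]1CC[C@H](NC(=O)c2cccc(-n3ccnc3)c2)CC1)[C@H]1CCc2nc(N)sc2C1` gives 1.1 nM;
compound 3 `CCCN(CC[C@H]1CC[C@H](NS(=O)(=O)c2cccc3ccccc23)CC1)[C@H]1CCc2nc(N)sc2C1` gives 1.5 nM.

The three numbers lie within the scatter of one another, so compound 3 cannot be separated from compound 1 or compound 2 on these data; all three sit at the low end of the range seen so far. Within the data shown here, the one step that changes an aromatic group, a 1.5-fold lower number from compound 1 to compound 2 (0.16 log units; within the scatter), concerns the amide side of the series and stays within the scatter.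

Compound 4 `CCCN(CC[C@H]1CC[C@H](NS(=O)(=O)c2ccc(Cl)nc2)CC1)[C@H]1CCc2nc(N)sc2C1` differs from compound 3 in the sulfonamide part: 6-chloropyridin-3-yl in place of naphthalen-1-yl on a sulfonyl sulfur. Among the measured compounds shown here, no measured step touches the group on the sulfonyl sulfur, so the only guidance is that the one aromatic swap seen, from compound 1 to compound 2, produced no shift beyond the scatter. On that basis a modest shift is expected, with some allowance for a loss, since the change leaves the part of the series that has been tested. The step from compound 3 to compound 4 is estimated at a 2.3-fold higher number from compound 3 to compound 4 (0.37 log units; beyond the scatter). Compound 4 is therefore expected to give about 3.5 nM, within a range of 1 nM to 12 nM.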

Compound 4, inhibition constant: 0.63 nM
Estimate against measurement, compound 4: 5.6-fold (0.74 log units) above; the whole stated range lies above it.
By their numbers in this assay, from the lowest: compounds 4, 2, 3 and 1 (each within the scatter of the next, the first and the last beyond it).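

On the sulfonyl sulfur, in this assay, the group can change from two carbon rings in naphthalen-1-yl to one ring in 6-chloropyridin-3-yl, with a ring nitrogen and a chlorine, and the number still falls, with a 2.4-fold lower number from compound 3 to compound 4 (0.38 log units; beyond the scatter). Among these compounds, the second ring of naphthalen-1-yl is therefore not required for low values at this position, and this is the first step to lie beyond the scatter, though it is modest. Nothing shown gives a cause for this step.

Among the compounds shown here, the single swap changes ring count, ring nitrogen and chlorine together, so the contribution of each stays unresolved. A plain phenyl, a pyridinyl without chlorine or a methyl on the sulfonyl sulfur would begin to separate them.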